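One Side Chain Exchanged on a Long-Lived Compound

The source may hold more compounds than are shown below. What is called first, only, known or untested is meant among the compounds shown, and "the series" means these compounds.

In an ADME assay on microsomes from liver (Rattus norvegicus) for metabolic stability (on this read-out higher numbers stand for a longer-lived compound and lower numbers for a shorter-lived compound), compound 1 (`CS(=O)(=O)N1CCN(CC(O)CN2CCC(CNC(=O)c3cccc4[nH]c(C5CC5)nc34)CC2)CC1`) gives > 1.5 h, which is a limit and not a number. Compound 2 (`CC(C)c1nc2c(C(=O)NCC3CCN(CCN4CCN(S(C)(=O)=O)CC4)CC3)cccc2[nH]1`) gives > 1.5 h, also a limit. Compound 2 therefore stands at the limit of > 1.5 h in this assay, at which 2 of the 2 values shown sit. Compound 3 (`COC(=O)N(C)CC(O)CN1CCC(CNC(=O)c2cccc3[nH]c(C(C)C)nc23)CC1`) carries one change from compound 2: 1-hydroxy-2-((methoxycarbonyl)(methyl)amino)ethyl in place of (4-(methylsulfonyl)piperazin-1-yl)methyl on a saturated chain carbon bound to an amine nitrogen in a ring. Among the measured compounds shown here, no measured pair shows what such a change does, so in this assay only a small fall, about the size of the usual scatter, is expected. The estimated step is a number no higher from compound 2 to compound 3 (the limit leaves the size open). Compound 3 is expected at 1.5 h, within a range from 0.6 h to 3 h.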

Compound 3, half-life: 1.32 h
Compound 3: middle estimate off by 1.1-fold (0.06 log units), on the high side; the range from low to high includes it.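

Among the compounds shown here, compound 3 is the first compound here to give a real number rather than a limit, so this position now has a measured value with an open-chain group on it. In this assay the exchange gives an at least 1.1-fold lower number from compound 2 to compound 3 (0.05 log units; that floor lies within the scatter), and that floor lies within the usual scatter. How large the step truly is cannot be read, since compound 2 sits at a limit: the limit of > 1.5 h in this assay, at which 2 of the 3 values shown sit.

The exchange removes a ring and brings in a hydroxy group at once, and the compounds shown do not separate the two. Going by these compounds, what a plain amine or a carboxylic acid at this place would do stays open.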